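The compounds below may be only part of what the source reports. "The series", "measured", "known", "first", "only" and "open" are said of these compounds alone.

Of the compounds shown here, two on related cores have so far been tested in a functional assay on A549 cells (Homo sapiens) for cytotoxicity, read by colorimetric assay and MTT assay, with a stated time of 72 h; a lower number here means a stronger inhibitor, a higher number a weaker inhibitor. Compound 1 `COC1(c2cc(=O)c3ccccc3o2)C=CC(=O)C=C1` returned only a limit, > 74600 nM, and not a number. Among the compounds with values here, compound 2 `O=C1C=CC(O)(c2cc(=O)c3c(O)cccc3o2)C=C1` gave 5070 nM, the only actual number available, so it cannot yet be ranked against a second measured value. Compound 3 `COC1(c2cc(=O)c3c(O)cccc3o2)C=CC(=O)C=C1` keeps the core of compound 2 with a single change, methyl in place of hydrogen on an oxygen on a saturated carbon, which turns hydroxy into methoxy. Within the data shown here, no measured pair shows this change alone. Among the measured compounds shown here, the one guide is compound 1, which also carries the methoxy and gave > 74600 nM, again a limit. A weakening beyond the scatter is therefore expected in this assay, with an expected size of a 3.6-fold higher number from compound 2 to compound 3 (0.55 log units; beyond the scatter). Compound 3 is estimated at 18000 nM, within an expected range of 6000 nM to 60000 nM.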

Compound 3, half-maximal inhibitory concentration: 57600 nM
Compound 3: middle estimate off by 3.2-fold (0.51 log units), on the low side, within the range that was stated.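

In this assay, the pair of compound 2 and compound 3 now isolates methyl in place of hydrogen on an oxygen on a saturated carbon, and it gives an 11-fold higher number from compound 2 to compound 3 (1.06 log units; beyond the scatter): at this position, hydroxy to methoxy is a large weakening. The second pair, with hydroxy in place of hydrogen on an aromatic carbon, gives an at least 1.2-fold lower number from compound 1 to compound 3 (0.11 log units; that floor lies within the scatter), so that change cannot be separated from the scatter. Compound 1 remains a limit, and the reading of that step rests on it: the limit of > 74600 nM in this assay, at which 1 of the 3 values shown sits.

The compounds shown leave open how an amine or an ethoxy group on that saturated carbon would compare with hydroxy and methoxy. They also leave open how hydroxy on that carbon would read on the core of compound 1, without hydroxy on the aromatic carbon.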